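Swapping a benzyl arm for a furan on the chain

The source may hold more compounds than are shown below. What is called first, only, known or untested is meant among the compounds shown, and "the series" means these compounds.

Among the compounds with values here, compound 3 `COc1ccc(F)cc1CNCCCNc1ccnc2cc(CCc3ccccc3)ccc12` is one of three compounds measured in a physicochemical assay for solubility, with a stated time of 18 h, at pH 7.4; on this read-out higher numbers stand for higher solubility and lower numbers for lower solubility. Compound 1 `Fc1ccc(-c2ccc3c(NCCCNCc4ccco4)ccnc3c2)cc1` gives 32000 nM, compound 2 `CC(C)CCc1ccc2c(NCCCNCc3ccco3)ccnc2c1` gives 4200 nM, and compound 3 gives 4200 nM, level with compound 2 and together with it at the low end of the three. Within the data shown here, the only step between measured neighbours, a 7.6-fold lower number from compound 1 to compound 2 (0.88 log units; beyond the scatter), concerns the group on the shared core rather than the chain.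

Compound 4 `c1ccc(CCc2ccc3c(NCCCNCc4ccco4)ccnc3c2)cc1` differs from compound 3 in the chain: furan-2-yl in place of 5-fluoro-2-methoxyphenyl on a saturated chain carbon bound to an amine nitrogen. Among the measured compounds shown here, no measured step touches this exact exchange, so the expectation must lean on the fact that compound 1 and compound 2 both carry the ((furan-2-yl)methyl)amino arm and span the whole range seen, while compound 4 keeps the core of compound 3.

For compound 4, a solubility of 8000 nM is therefore estimated, between 3000 nM and 25000 nM, which means an expected step of a 1.9-fold higher number from compound 3 to compound 4 (0.28 log units; within the scatter), leaning toward a modest rise but not confidently beyond the scatter.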

Compound 4, solubility: 4200 nM
Beside the measured number, compound 4's estimate is 1.9-fold (0.28 log units) above it; measured number inside the range.
By their numbers in this assay, from the lowest: compounds 2, 3 and 4 (each within the scatter of the next); then compound 1.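

In this assay, furan-2-yl in place of 5-fluoro-2-methoxyphenyl on a saturated chain carbon bound to an amine nitrogen gives no change at the digits printed from compound 3 to compound 4 (within the scatter) and so, with the phenethyl group on the core, this read-out does not separate the two arms. With the furan-2-yl arm held fixed, the core group gives no change at the digits printed from compound 2 to compound 4 (within the scatter) for phenyl in place of isopropyl, but a 7.6-fold lower number from compound 1 to compound 4 (0.88 log units; beyond the scatter) for phenethyl in place of 4-fluorophenyl, so among these compounds only the 4-fluorophenyl compound stands apart. Nothing shown here offers an explanation for these numbers.

From the compounds shown here alone, whether the two arms would also read alike on the core of compound 1 remains open. Also open, going by these compounds, is how a carboxylic acid or a morpholine in place of furan-2-yl, or a longer chain, would read in this assay on this core.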